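The compounds below may be only part of what the source reports. "The series", "measured", "known", "first", "only" and "open" are said of these compounds alone.

Of the compounds shown here, three built on one shared core have been measured so far. Compound 1 `CC(C)(C)c1ccc(-n2nc(-c3ccc(C(F)(F)F)cc3O)nc2-c2ccccc2O)cc1` gives 77.8% in a functional assay on PC-12 cells (Rattus norvegicus) for cytotoxicity, read by MTT assay, with stated times of 2 h and 24 h, tested at 5 uM; on this read-out lower numbers stand for a weaker effect and higher numbers for a stronger effect at the one concentration tested. Compound 2 `N#Cc1ccc(-n2nc(-c3ccc(C(F)(F)F)cc3O)nc2-c2ccccc2O)cc1` gives 86.8%, and compound 3 `Oc1cc(C(F)(F)F)ccc1-c1nc(-c2ccccc2O)n(-c2ccccc2F)n1` gives 86.6%. On these three numbers compound 3 stands second highest; its nearest neighbour is compound 2 and its furthest is compound 1, yet both gaps fall within the usual scatter of this kind of measurement, so the three compounds cannot really be told apart.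

Compound 4 `COc1cccc(-n2nc(-c3ccc(C(F)(F)F)cc3O)nc2-c2ccccc2O)c1` has not yet been measured. It differs from compound 3 in a single place: 3-methoxyphenyl in place of 2-fluorophenyl on an aromatic nitrogen. Two of the steps already seen concern the same aromatic nitrogen. The exchange of a 4-(tert-butyl)phenyl for a 2-fluorophenyl there gave a number 8.8 percentage points higher from compound 1 to compound 3 (within the scatter), and the exchange of a 4-cyanophenyl for a 2-fluorophenyl gave a number 0.2 percentage points lower from compound 2 to compound 3 (within the scatter). Neither change on this nitrogen moved the read-out beyond the scatter, and the remaining step, a number 9 percentage points higher from compound 1 to compound 2 (within the scatter), stayed within it as well. On that basis no step beyond the scatter is expected for compound 4, and the estimated step is a number 1.6 percentage points lower from compound 3 to compound 4 (within the scatter). For compound 4 the estimate is therefore 85%, with a range from 72% to 95%.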

Compound 4, a percentage reported as activity, at one concentration (the size of the read-out at that concentration, not a potency): 96.8%
For compound 4 the middle estimate is 11.8 percentage points below the measured one; measured number outside the range, above it.
By their numbers in this assay, from the lowest: compounds 1, 3, 2 and 4 (each within the scatter of the next, the first and the last beyond it).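

For the compounds shown here, on this aromatic nitrogen, a change of the aryl group can carry the read-out in this assay beyond the scatter, which no earlier step did: 3-methoxyphenyl in place of 2-fluorophenyl gives a number 10.2 percentage points higher from compound 3 to compound 4 (beyond the scatter) and 3-methoxyphenyl in place of 4-(tert-butyl)phenyl gives a number 19 percentage points higher from compound 1 to compound 4 (beyond the scatter) on the same nitrogen. The gain is slight and depends on the comparison, since 3-methoxyphenyl in place of 4-cyanophenyl gives a number 10 percentage points higher from compound 2 to compound 4 (within the scatter) and compound 4 therefore cannot be told apart from compound 2, even though compound 2 and compound 3 also lie within the scatter of each other. No measurement offered here accounts for this step.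

As far as these compounds go, it remains open whether the step belongs to the methoxy group itself or to where that group sits on the phenyl ring, a question that 4-methoxyphenyl on the same nitrogen would address. Also open, from the compounds shown here alone, is whether a 3-ethoxyphenyl with its longer chain, or a 3-aminophenyl carrying an amine, would give a number like that of compound 4 or one closer to that of compound 3.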